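The source may report more compounds than this note shows. Statements on the series, on what has been measured and on what is new or still open speak of the compounds shown alone.

Compound 2 `C=CCCC(=O)N[C@H]1[C@@H](OCCCCCCCCCCCCCCCC)O[C@H](CO)[C@@H](O)[C@@H]1O` is one of three compounds examined in a functional assay on A-375 cells (Homo sapiens), read by thymidine incorporation; on this read-out lower numbers stand for stronger inhibition and higher numbers for weaker inhibition. In this assay compound 2 gives only a limit, > 50 uM. Compound 1 `CCCCCCCCCCCCCCCCO[C@H]1O[C@H](CO)[C@@H](O)[C@H](O)[C@H]1NC(C)=O` carries hydrogen where compound 2 carries allyl on the saturated chain carbon bound to the carbonyl carbon, and in this assay compound 1 gives 29.3 uM. The step of an at least 1.7-fold higher number from compound 1 to compound 2 (0.23 log units; that floor lies within the scatter) is therefore known only as a floor, and that floor lies within the scatter. Compound 3 `CCCCC(=O)N[C@H]1[C@@H](OCCc2ccccc2)O[C@H](COCC(CO)(CO)CO)[C@@H](O)[C@@H]1O`, with a different amide and a different ether chain, also gives only a limit in this assay, > 50 uM. Compound 2 thus stands at the edge of what the numbers can show, and the limit of > 50 uM in this assay, at which 2 of the 3 values shown sit, marks how much of the set sits there.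

Compound 4 `C=CCCC(=O)N[C@H]1[C@@H](OCCCCCCCCCCCCCCCC)O[C@H](CO)[C@@H](O)[C@@H]1OS(=O)(=O)O` differs from compound 2 by sulfo in place of hydrogen on an oxygen on a saturated carbon; read one bond further out, hydroxy becomes sulfooxy. For the measured compounds named here, no measured step mirrors this change: the single-place step from compound 1 to compound 2 concerns the amide side and is itself only a floor. The expectation for compound 4 in this assay is therefore a step that the limit leaves unreadable from compound 2 to compound 4 that does not exceed the scatter, with the result most likely again a limit. Compound 4 is estimated at 65 uM, within 20 uM to 250 uM.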

Compound 4, concentration for 50% inhibition: 7.2 uM
For compound 4 the middle estimate is 9.0-fold (0.96 log units) above the measured one, outside the stated range (below it).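

In this assay, sulfo in place of hydrogen on an oxygen on a saturated carbon gives an at least 6.9-fold lower number from compound 2 to compound 4 (0.84 log units; beyond the scatter), and compound 4 carries a measured value of 7.2 uM. For the compounds shown here, this is the first step in the set that reads as beyond the scatter, and it lies at this oxygen, whereas the only earlier step, on the amide side, has a floor within the scatter. Compound 2 is known only as a limit, so the change is shown to matter but its full size stays unknown, and such limits still mark a large share of the set: the limit of > 50 uM in this assay, at which 2 of the 4 values shown sit.

The compounds shown leave open whether this gain is specific to sulfooxy or would also appear with a phosphate or a carboxylic acid on the same oxygen, or with an amine there instead. They also leave open whether sulfooxy on another oxygen of the core would act alike, and whether the step would hold with a shorter chain on the ether oxygen or with a different amide.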